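Replacing naphthalen-1-yl with 4-fluorophenyl in the series

The source may hold more compounds than are shown below. What is called first, only, known or untested is meant among the compounds shown, and "the series" means these compounds.

Measured compounds:
Compound 1 `Cc1cc(Nc2ccn(Cc3cccc4ccccc34)n2)n2nc(SCc3ccc(Br)cc3)nc2n1`: 3240 nM
Compound 2 `Cc1cc(Nc2cc(-c3ccc(Cl)cc3)[nH]n2)n2nc(SCc3ccc(Br)cc3)nc2n1`: 2780 nM
Compound 3 `Cc1cc(Nc2cc(-c3ccccc3)[nH]n2)n2nc(SCc3ccccc3Br)nc2n1`: 3650 nM

In a functional assay on MGC-803 cells (Homo sapiens) for inhibition, read by MTT assay, with a stated time of 72 h (a higher number here means a weaker inhibitor, a lower number a stronger inhibitor), compound 1 gives 3240 nM, the second highest of the three numbers. Compound 3 and compound 2 both lie within the usual scatter of compound 1, so the three cannot be placed in any order on these data. Compound 4 `Cc1cc(Nc2ccn(Cc3ccc(F)cc3)n2)n2nc(SCc3ccc(Br)cc3)nc2n1` differs from compound 1 by 4-fluorophenyl in place of naphthalen-1-yl on a saturated chain carbon bound to an aromatic nitrogen. Going by the values given here, no measured pair shows this change, and all three measured compounds keep the same core with only peripheral groups exchanged, so the size of the step has no precedent here. The step of a 1.2-fold higher number from compound 1 to compound 4 (0.07 log units; within the scatter) is expected to stay within the scatter, if anything leaning toward a higher number. Compound 4 is therefore estimated at 3800 nM, between 1500 nM and 9500 nM.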

Compound 4, half-maximal inhibitory concentration: 3070 nM
Estimate against measurement, compound 4: 1.2-fold (0.09 log units) above; the measured number falls inside the stated range.
By their numbers in this assay, from the lowest: compounds 2, 4, 1 and 3 (each within the scatter of the next).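

In this assay, 4-fluorophenyl in place of naphthalen-1-yl on a saturated chain carbon bound to an aromatic nitrogen gives a 1.1-fold lower number from compound 1 to compound 4 (0.02 log units; within the scatter). Going by these compounds alone, this is the first pair differing in one place, and it shows that one six-membered aromatic ring of carbon only can stand here for two without the compounds being told apart. Nothing measured on these compounds offers an explanation for this result.

Open, from the compounds shown here alone, is whether an amine or a carboxylic acid in place of 4-fluorophenyl would move the number beyond the scatter. Also open, going by these compounds, is whether this step holds with other groups on the shared core.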